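A few compounds are considered here, and "the series" means these few. Any claim that something is new, unique, unknown or untested is made for them only; others in the source may bear on it.

Compound 2 (`COCCOc1cc2c(-n3nc(-c4ccccn4)nc3N)ncnc2cc1OC`) gives < 8.3 mL/min/kg in an ADME assay on liver for metabolic stability, with Liver microsome (Canis lupus familiaris) as the target, read by HPLC, using microsomes, with a stated time of 4 h (on this read-out higher numbers stand for fast clearance and lower numbers for slow clearance), and this is a limit of the assay, not a number. Compound 1 (`COCCOc1cc2ncnc(-n3nc(-c4ccccn4)nc3N)c2cc1OCCOC`) gives < 8.3 mL/min/kg in this assay and this too is only a limit. Compound 2 therefore has no readable position, only a ceiling shared with compound 1.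

Going on to compound 3 (`COc1cc2ncnc(-n3nc(-c4ccccn4)nc3N)c2cc1OCCCNC(=O)OC(C)C`) the change is ((isopropoxycarbonyl)amino)methyl in place of methoxy on a saturated chain carbon, two bonds along the chain from an oxygen on an aromatic ring and, cut one bond further out, it reads 2-methoxyethoxy to 3-((isopropoxycarbonyl)amino)propoxy.

Going by the values given here, the one measured step, a step that the two limits leave unreadable from compound 1 to compound 2, has limits at both ends and gives no size to carry over. Among the compounds with values here, no measured compound carries the incoming group. The expectation stays close to compound 2 because the limit of < 8.3 mL/min/kg in this assay, at which 2 of the 2 values shown sit, is the only anchor available.

The expected move is an at least 1.0-fold higher number from compound 2 to compound 3 (0.03 log units; that floor lies within the scatter) and it is not expected to exceed the scatter, though any readable shift could only be upward. For compound 3 the estimated clearance is 9 mL/min/kg (range 5 mL/min/kg to 18 mL/min/kg) and the assay may well report only a limit again.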

Compound 3, clearance: < 7.9 mL/min/kg
Compound 3 ended at the assay's limit; the forecaster's own chance of this, stated with the estimate: 50%; middle value at least 1.1-fold (0.05 log units) away from the limit.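

In this assay compound 3 gives < 7.9 mL/min/kg, which is a limit of the assay and not a number. Compound 2 also stands only at a limit, so the step from it to compound 3 cannot be read. The compounds shown leave open what the actual clearance of compounds 1, 2 and 3 is, and whether ((isopropoxycarbonyl)amino)methyl in place of methoxy shifts it at all.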